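From Isopropoxy to Ethylamino on a Carbonyl Carbon

The source may hold more compounds than are shown below. What is called first, only, known or untested is meant among the compounds shown, and "the series" means these compounds.

Measured so far in an ADME assay on HeLa cells (Homo sapiens) for cytotoxicity, read by MTT assay, with a stated time of 2 days (a higher number here means that more compound is tolerated, a lower number that less compound is tolerated), as follows
- compound 1 `CCOC(=O)c1cc2ccc(Oc3ccnc(C(=O)NC)c3)cc2s1` gives > 100000 nM as a limit
- compound 2 `CNC(=O)c1cc(Oc2ccc3cc(C(=O)OC(C)C)sc3c2)ccn1` gives 45000 nM
- compound 3 `CNC(=O)c1cc(Oc2ccc3c(C)c(C(=O)OC(C)C)sc3c2)ccn1` gives 9600 nM

The value of compound 1 is a limit of the assay, not a number. Of the two true numbers, compound 3 holds the lower one, and its nearest neighbour is compound 2, as a 4.7-fold lower number from compound 2 to compound 3 (0.67 log units; beyond the scatter) shows. Compound 4 `CCNC(=O)c1sc2cc(Oc3ccnc(C(=O)NC)c3)ccc2c1C`, not yet measured, carries ethylamino in place of isopropoxy on a carbonyl carbon. The closest measured step is an at least 2.2-fold lower number from compound 1 to compound 2 (0.34 log units; beyond the scatter), which ends in the isopropoxy that now leaves. The step of a 4.7-fold lower number from compound 2 to compound 3 (0.67 log units; beyond the scatter) concerns a methyl on an aromatic carbon that compound 4 keeps, so it gives only a rough guide to size. Among the compounds with values here, no measured compound carries ethylamino, so the direction is uncertain, but a modest move to a higher number is expected. The estimated change is a 2.3-fold higher number from compound 3 to compound 4 (0.36 log units; beyond the scatter) in this assay overall. Compound 4 is expected at 22000 nM with a range from 7000 nM to 70000 nM as the estimate.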

Compound 4, half-maximal cytotoxic concentration: > 100000 nM
Compound 4: no number, only a limit (the forecaster's own chance of this, stated with the estimate: 15%); middle value at least 4.5-fold (0.65 log units) from the limit.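

In this assay, within the data shown here, an at least 10-fold higher number from compound 3 to compound 4 (1.01 log units; beyond the scatter) shows that the group on this carbonyl carbon can matter a great deal: the earlier compounds varied only the ester here, whereas ethylamino replaces the oxygen link with a nitrogen link and carries a hydrogen-bond donor. The methyl on the aromatic carbon, which came with a lower number in a 4.7-fold lower number from compound 2 to compound 3 (0.67 log units; beyond the scatter), is still present in compound 4, so this methyl alone does not keep the number low once ethylamino stands on the carbonyl carbon. Compound 4 gives > 100000 nM, which is a limit of the assay and not a number, so only a floor for the step can be read: the limit of > 100000 nM in this assay, at which 2 of the 4 values shown sit.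

The compounds shown leave open whether the change follows the nitrogen or the shape of the chain, which isopropylamino on the same carbonyl carbon would separate. They also leave open how a free carboxylic acid there would read, and whether ethylamino would read the same without the aromatic methyl.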